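Removing one chlorine from a lone measured compound

The compounds below may be only part of what the source reports. "The series", "measured", "known", "first", "only" and "open" are said of these compounds alone.

- compound 1 `NC1=NC2(CCSCC2)N(OCCCOc2ccc(Cl)c(Cl)c2)C(N)=N1`: 70 nM
- compound 2 `NC1=NC2(CCOCC2)N(OCCCOc2ccccc2)C(N)=N1`: "not determined" (no result reported)

For the measured compounds named here, in a functional assay on HepG2 cells (Homo sapiens) for antiproliferative activity, read by MTT assay, with a stated time of 72 h (on this read-out higher numbers stand for weaker inhibition and lower numbers for stronger inhibition), compound 1 gives 70 nM and is the only compound with a number, since compound 2 has no reported result. That single value offers no ranking, only a starting point. Compound 3 `NC1=NC2(CCSCC2)N(OCCCOc2cccc(Cl)c2)C(N)=N1` has yet to be measured and differs from compound 1 in one place (hydrogen in place of chloro on an aromatic carbon): hydrogen in place of chloro on an aromatic carbon, taking 3,4-dichlorophenyl to 3-chlorophenyl. Going by the values given here, no measured pair shows what such a change does here, so any forecast is uncertain. A modest move towards weaker inhibition, meaning a higher number, is expected in this assay and may not clear the usual scatter by much. The estimated change is a 2.1-fold higher number from compound 1 to compound 3 (0.33 log units; beyond the scatter) (an expectation, not a result). Compound 3 is estimated at 150 nM (expected range 50 nM to 450 nM).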

Compound 3, half-maximal inhibitory concentration: 90 nM
Compound 3: the middle estimate sits 1.7-fold (0.22 log units) above what was measured; the measured number falls inside the stated range.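

Replacing the chloro group para to a large group with hydrogen, which takes 3,4-dichlorophenyl to 3-chlorophenyl, gives a 1.3-fold higher number from compound 1 to compound 3 (0.11 log units; within the scatter) in this assay. Compound 1 and compound 3 therefore cannot be told apart in these cells, so this one change on the ring, with one chloro group left in place, gives a number that stays within the usual variation between repeats. Nothing at hand explains this result.

The compounds shown leave open whether the remaining chloro group matters, or whether a ring with no chloro group at all would read the same on this core. They also leave open whether a different group at the position just emptied, such as fluoro, methoxy or an amine, would shift the number beyond the scatter.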